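A few compounds are considered here, and "the series" means these few. Any claim that something is new, unique, unknown or untested is made for them only; others in the source may bear on it.

Measured so far in a functional assay on NCI-H460 cells (Homo sapiens) for cytotoxicity (a lower number here means a stronger inhibitor, a higher number a weaker inhibitor), the numbers are:

- compound 1 `CS(=O)(=O)c1ccc2nc(NC(=O)CCCCCCC(=O)NO)sc2c1` gives 6.54 ug/mL
- compound 2 `O=C(CCCCCCC(=O)Nc1nc2ccc([N+](=O)[O-])cc2s1)NO` gives 1.9 ug/mL
- compound 3 `CCOc1ccc2nc(NC(=O)CCCCC(=O)NO)sc2c1` gives 7.96 ug/mL

Compound 3 and compound 1 lie within the scatter of each other, while compound 2 has a clearly lower number than either. Compound 4 `CCOc1ccc2nc(NC(=O)CCCCCCC(=O)NO)sc2c1` differs from compound 3 in one place, on a saturated chain carbon, four bonds along the chain from a carbonyl carbon, where 2-(hydroxycarbamoyl)ethyl stands in place of hydroxycarbamoyl (2-(hydroxycarbamoyl)ethyl in place of hydroxycarbamoyl on a saturated chain carbon, four bonds along the chain from a carbonyl carbon). This gives compound 4 the longer chain already found in compound 1 and compound 2.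

Within the data shown here, no measured step covers this change directly. The only one, a 3.4-fold lower number from compound 1 to compound 2 (0.54 log units; beyond the scatter), swaps methylsulfonyl for nitro on an aromatic carbon and leaves the chain untouched. Among the measured compounds shown here, with the longer chain, compound 1 gives 6.54 ug/mL and compound 2 gives 1.9 ug/mL, so a modest fall in the number is expected in this assay, though no measured pair confirms it. The step expected is a 2.1-fold lower number from compound 3 to compound 4 (0.32 log units; beyond the scatter), an estimate resting on very few data. For compound 4 the estimated value is 3.8 ug/mL, with an expected range from 1.3 ug/mL to 10 ug/mL, which is wide.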

Compound 4, half-maximal inhibitory concentration: 6.58 ug/mL
Beside the measured number, compound 4's estimate is 1.7-fold (0.24 log units) below it; measured number inside the range.
By their numbers in this assay, from the lowest: compound 2; then compounds 1, 4 and 3 (each within the scatter of the next).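

In this assay the change from hydroxycarbamoyl to 2-(hydroxycarbamoyl)ethyl on this saturated chain carbon, with ethoxy held fixed on the core, gives a 1.2-fold lower number from compound 3 to compound 4 (0.08 log units; within the scatter) and so shows no clear effect of the longer chain. With the longer chain held fixed, the aromatic carbon is where the numbers part: ethoxy in place of nitro gives a 3.5-fold higher number from compound 2 to compound 4 (0.54 log units; beyond the scatter) while ethoxy in place of methylsulfonyl gives a 1.0-fold higher number from compound 1 to compound 4 (0.00 log units; within the scatter) and leaves those two compounds indistinguishable. Among the three longer-chain compounds, compound 2 alone has a clearly lower number.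

No other measurement here helps to explain these numbers. Still open, going by these compounds, are whether the chain change would also make no clear difference with nitro on the aromatic carbon, and how an amine or a carboxylic acid on that carbon would compare.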